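Two methyl groups in place of one on a phenoxy ether

This account rests on a few compounds, and the source may have more. Where it says the series, first, only, none or still open, it means among the compounds named here.

Compound 1 `Cc1ccc(OCCCON2C(N)=NC(N)=NC23CCOCC3)cc1`: "not determined" (no result reported)
Compound 2 `NC1=NC2(CCSCC2)N(OCCCOc2ccc(Cl)cc2)C(N)=N1`: "not determined" (no result reported)
Compound 3 `CC(C)(C)c1ccc(OCCCON2C(N)=NC(N)=NC23CCSCC3)cc1`: 86.6%

Three compounds share a core carrying two amino groups and a propyl linker that ends in an aryl ether. For the measured compounds named here, in an assay on isolated protein for inhibition of Dihydrofolate reductase (Homo sapiens), read by spectrophotometry, using NADPH, with stated times of 5 s and 6 min, tested at 50 uM (on this read-out higher numbers stand for a stronger effect at the one concentration tested and lower numbers for a weaker effect), compound 3 gives 86.6%, the only number in the set. For compound 1 no result has been obtained in this assay, so it cannot be placed against compound 3, and the same holds for compound 2. Compound 4 `Cc1cc(C)cc(OCCCON2C(N)=NC(N)=NC23CCOCC3)c1` differs from compound 1 by 3,5-dimethylphenyl in place of 4-methylphenyl on an oxygen on a saturated carbon. Going by the values given here, with no numbers for compound 1, no step between them can be quantified; the expectation is that this change produces no difference beyond the usual scatter of this assay, so compound 4 should stand near where compound 1 would, which in turn is taken to resemble compound 3 on the strength of its 86.6%. Compound 4 is therefore estimated at 75%, with a likely range from 50% to 95%.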

Compound 4, a percentage reported as inhibition, at one concentration (the size of the read-out at that concentration, not a potency): 88.6%
For compound 4 the middle estimate is 13.6 percentage points below the measured one; measured number inside the range.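

No step can be read between compound 1 and compound 4, as only compound 4 has a number. As far as these compounds go, what exchanging 4-methylphenyl for 3,5-dimethylphenyl does on its own remains open, and no available evidence bears on the result.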